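This account rests on a few compounds, and the source may have more. Where it says the series, first, only, none or still open, it means among the compounds named here.

Measured so far in an ADME assay on S9 fraction from liver (Rattus norvegicus) for metabolic stability, read by LC-MS, using NADPH, with a stated time of 30 min; on this read-out lower numbers stand for a less stable compound and higher numbers for a more stable compound:
- compound 1 `CCCCCCCCc1ccc(OCC(=O)Cn2ncnn2)cc1`: < 5%
- compound 2 `CCCCCCCCc1ccc(OCC(=O)Cn2nnc(-c3ccc(C(=O)OC)cc3)n2)cc1`: 64%
- compound 3 `CCCCCCCCc1ccc(OCC(=O)Cn2nnc(-c3cccc(C(=O)OC)c3)n2)cc1`: 19%

The entry for compound 1 is a limit of the assay and not a number: < 5%.

Compound 3, at 19%, sits well under compound 2, which reaches 64%, so it has the lower of the two true numbers. The next compound, compound 4 `CCCCCCCCc1ccc(OCC(=O)Cn2nnc(-c3cccc(S(=O)(=O)N(C)C)c3)n2)cc1`, keeps everything in compound 3 except one group: dimethylsulfamoyl in place of methoxycarbonyl on an aromatic carbon. In words, dimethylsulfamoyl replaces methoxycarbonyl on an aromatic carbon, meta to a large group.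

Within the data shown here, no measured step makes this exact swap, so the evidence is indirect. Adding the 3-(methoxycarbonyl)phenyl group gave a number at least 14 percentage points higher from compound 1 to compound 3 (beyond the scatter). Changing 4-(methoxycarbonyl)phenyl to 3-(methoxycarbonyl)phenyl gave a number 45 percentage points lower from compound 2 to compound 3 (beyond the scatter). These steps show that this part of the molecule can move the read-out strongly, but not which way a new group will push it. The value of compound 3 is therefore the best anchor, and no step beyond the usual scatter is expected, though the uncertainty is wide. The expected change is a number 3 percentage points higher from compound 3 to compound 4 (within the scatter).

The estimate for compound 4 is 22%, with an expected range from 7% to 50%.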

Compound 4, percent of the compound remaining: 9%
Compound 4: the middle estimate sits 13 percentage points above what was measured; low and high end bracket the measured number.
By their numbers in this assay, from the lowest: compounds 4 and 3 (each within the scatter of the next); then compound 2. At a limit, below all of these: compound 1.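

In this assay, putting dimethylsulfamoyl in place of methoxycarbonyl on an aromatic carbon, meta to a large group, gives a number 10 percentage points lower from compound 3 to compound 4 (within the scatter), so at this position the two groups cannot be told apart, even though they differ in their atoms. Among these compounds, the larger gap, a number 55 percentage points lower from compound 2 to compound 4 (beyond the scatter), is a different matter: it changes both the group and where it sits on the phenyl ring, so this step alone cannot assign the gap to either change, and only the step from compound 2 to compound 3 isolates the place of the group. The remaining step, a number at least 4 percentage points higher from compound 1 to compound 4 (that floor lies within the scatter), does not show a difference that can be relied on. Compound 1 gives < 5%, which is a limit and not a number: the limit of < 5% in this assay, at which 1 of the 4 values shown sits.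

As far as these compounds go, it remains open whether dimethylsulfamoyl would reach the level of compound 2 if it were carried as the methoxycarbonyl is in the 4-(methoxycarbonyl)phenyl group. From the compounds shown here alone, it is equally open how a carboxylic acid or an amine would behave at the position held by methoxycarbonyl in compound 3.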